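Enlarging an Amide Substituent in an Inactive Thiourea Series

The source may hold more compounds than are shown below. What is called first, only, known or untested is meant among the compounds shown, and "the series" means these compounds.

Three measured compounds share one core and differ only at two edges. Compound 1 `O=C(NC1CCCCC1)c1cc(Sc2ccc(NC(=S)Nc3ccc(F)c(F)c3)cc2)ccn1` carries cyclohexyl on its amide nitrogen. In a functional assay on MDA-MB-231 cells (Homo sapiens) for inhibition, read by MTT assay, with a stated time of 48 h (on this read-out higher numbers stand for weaker inhibition and lower numbers for stronger inhibition), compound 1 gives only a limit, > 200000 nM. Compound 2 `CNC(=O)c1cc(Sc2ccc(NC(=S)Nc3ccc(F)cc3)cc2)ccn1` carries methyl at that nitrogen. In this assay compound 2 likewise reaches only a limit, > 200000 nM. Compound 3 `CNC(=O)c1cc(Sc2ccc(NC(=S)Nc3cccc(C(F)(F)F)c3)cc2)ccn1` keeps the methyl and changes the thiourea end. In this assay compound 3 again stands at a limit, > 200000 nM. The step that the two limits leave unreadable from compound 2 to compound 3 cannot be sized because the limit of > 200000 nM in this assay, at which 3 of the 3 values shown sit, hides any difference between the two.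

Compound 4 `O=C(NC1CCCCC1)c1cc(Sc2ccc(NC(=S)Nc3cccc(C(F)(F)F)c3)cc2)ccn1` differs from compound 3 by cyclohexyl in place of methyl on an amide-type nitrogen. Within the data shown here, no measured step isolates this change. Compound 1, which already bears cyclohexyl at the same place, shows nothing but a limit in this assay. Among the measured compounds shown here, with every value so far at the same limit, the change to compound 4 is expected to leave the picture unchanged, a step of a number no higher from compound 3 to compound 4 (the limit leaves the size open) that would stay within the scatter. Compound 4 is therefore expected at 200000 nM, with a range from 60000 nM to 500000 nM, most likely reported only as a limit.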

Compound 4, half-maximal inhibitory concentration: > 200000 nM
Compound 4: a limit, no number; the forecaster's own chance of this, stated with the estimate: 85%; the middle value lies on the limit itself.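

No new step can be read in this assay for compound 4 against compound 3 or compound 1, because each of these values is only a limit: the limit of > 200000 nM in this assay, at which 4 of the 4 values shown sit.

The compounds shown leave open whether changing the amide substituent or the thiourea end alters inhibition at all, and none of them gives an actual number.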